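Amide nitrogen substituent on a shared core: paw edema

The source may hold more compounds than are shown below. What is called first, only, known or untested is meant among the compounds shown, and "the series" means these compounds.

Measured compounds:
compound 1, `O=C(Nc1ccccn1)c1c(O)c2cccnc2n(-c2ccccc2)c1=O`, 14.6%
compound 2, `CCCCNC(=O)c1c(O)c2cccnc2n(-c2ccccc2)c1=O`, 20.4%

In a functional assay on the whole organism for inhibition, with Rattus norvegicus as the target, read by cytopathic effect and paw edema, at a dose of 100 mg/kg by the oral route (a higher number here means more inhibition at the dose given (going by the name of the read-out), a lower number less inhibition), compound 1 gives 14.6%, the lower of the two numbers, and compound 2 gives 20.4%. Among the compounds with values here, the only step between measured compounds, a number 5.8 percentage points higher from compound 1 to compound 2 (within the scatter), exchanges the group on the amide-type nitrogen and stays within the scatter, so the two values cannot be ordered.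

Compound 3, `O=C(Nc1cccc([N+](=O)[O-])c1)c1c(O)c2cccnc2n(-c2ccccc2)c1=O`, differs from compound 1 in one place: 3-nitrophenyl in place of pyridin-2-yl on an amide-type nitrogen. Within the data shown here, the step from compound 1 to compound 2 is the one measured change at the same position and bears on this one, though it introduces a different group; it was small. Among the measured compounds shown here, no measured compound carries 3-nitrophenyl, so nothing beyond the scatter is expected in this assay from the change. For compound 3 the expected step is a number 2.4 percentage points higher from compound 1 to compound 3 (within the scatter). Compound 3 is estimated at 17%, with a range from 4% to 32%.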

Compound 3, a percentage reported as inhibition, in the whole organism at one dose (the size of the read-out at that dose, not a potency): 7.4%
Compound 3: the middle estimate sits 9.6 percentage points above what was measured; the measured number falls inside the stated range.
By their numbers in this assay, from the lowest: compounds 3, 1 and 2 (each within the scatter of the next, the first and the last beyond it).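

In this assay, within the data shown here, the group on the amide-type nitrogen now gives a first step beyond the scatter, a number 13 percentage points lower from compound 2 to compound 3 (beyond the scatter) and modest in size, so exchanging butyl for 3-nitrophenyl at this nitrogen can move the read-out. The exchange of one aromatic group for the other, a number 7.2 percentage points lower from compound 1 to compound 3 (within the scatter) in this series, does not separate pyridin-2-yl from 3-nitrophenyl, and compound 1 stays within the scatter of both other compounds. Nothing available explains the gap between the butyl and 3-nitrophenyl amides.

With a single chain and two aromatic groups, the contrast rests on one pair and cannot yet be assigned to chains versus aromatic rings in general. Open too, going by these compounds, is where a longer chain such as hexyl, or an unsubstituted phenyl on this nitrogen, would fall.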